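Swapping propylsulfanyl for anilino on a shared core

A few compounds are considered here, and "the series" means these few. Any claim that something is new, unique, unknown or untested is made for them only; others in the source may bear on it.

Values in a functional assay on the whole organism with Mus musculus as the target; a higher number here means that more compound is needed for the effect, a lower number that less compound is needed:
- Compound 1 `Cc1c(C)c2c(c(C)c1N)CC(C)(CSc1ccc(O)cc1)O2`: > 50 mg/kg (a limit, not a number)
- Compound 2 `Cc1c(C)c2c(c(C)c1N)CC(C)(CSCc1ccccc1)O2`: 32 mg/kg
- Compound 3 `CCCSCC1(C)Cc2c(C)c(N)c(C)c(C)c2O1`: 24.6 mg/kg

Compound 3 gives 24.6 mg/kg, which lies within the usual scatter of compound 2 at 32 mg/kg. Compound 4 `Cc1c(C)c2c(c(C)c1N)CC(C)(CNc1ccccc1)O2` carries anilino in place of propylsulfanyl on a saturated chain carbon bound to a saturated ring carbon. Going by the values given here, no measured step makes this exact change. Replacing phenyl with ethyl on a saturated chain carbon bound to a sulfur gave a 1.3-fold lower number from compound 2 to compound 3 (0.11 log units; within the scatter). Replacing 4-hydroxyphenyl on a sulfur with propyl gave an at least 2.0-fold lower number from compound 1 to compound 3 (0.30 log units; that floor lies within the scatter). Neither step points to a large effect, so no step beyond the scatter is expected in this assay. The estimated step is a 1.4-fold higher number from compound 3 to compound 4 (0.15 log units; within the scatter). For compound 4 the expected dose is 35 mg/kg, with an estimated range from 14 mg/kg to 80 mg/kg.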

Compound 4, dose for 50% inhibition: 15.7 mg/kg
For compound 4 the middle estimate is 2.2-fold (0.35 log units) above the measured one; the range from low to high includes it.
By their numbers in this assay, from the lowest: compounds 4, 3 and 2 (each within the scatter of the next, the first and the last beyond it). At a limit, above all of these: compound 1.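

In this assay, putting anilino in place of propylsulfanyl gives a 1.6-fold lower number from compound 3 to compound 4 (0.20 log units; within the scatter). The earlier compounds shown here all held a sulfur on this chain carbon, so compound 4 adds something new: a nitrogen-linked aromatic ring can stand here, with more heavy atoms than propylsulfanyl, and the dose needed stays within the scatter of compound 3. One value in the series remains a limit, not a number: the limit of > 50 mg/kg in this assay, at which 1 of the 4 values shown sits.

The compounds shown leave open whether a phenoxy group or a simple primary amine would fit at this place. They also leave open whether a chlorine on the anilino ring would move the dose beyond the scatter.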